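The source may hold more compounds than are shown below. What is called first, only, known or untested is meant among the compounds shown, and "the series" means these compounds.

Compound 3, with the structure `CC(CCNC(=O)c1c(Cl)cncc1Cl)N1CCC(C(O)c2ccc(Br)cc2)CC1`, gives 198000 nM in an ADME assay on PBMC cells (Homo sapiens) for cytotoxicity (on this read-out higher numbers stand for lower toxicity in this test and lower numbers for higher toxicity in this test), the highest of the three numbers recorded there. Compound 1, `CC(CCNC(=O)c1c(Cl)cncc1Cl)N1CCC(C(=O)c2ccc(Br)cc2)CC1`, gives 189000 nM in this assay, and the step of a 1.0-fold higher number from compound 1 to compound 3 (0.02 log units; within the scatter) shows that the hydroxymethyl compound and the carbonyl compound cannot be told apart in this assay. Within the data shown here, compound 2, `CC(CCNC(=O)c1c(Cl)cncc1Cl)N1CCC(C(Oc2cccc(C#N)n2)c2ccc(C(F)(F)F)cc2)CC1`, gives 15700 nM in this assay, a number far lower than that of compound 3, beyond the scatter; compound 2 differs from compound 3 in two places at once, so no single step between them is known.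

Compound 4, `CC(CCNC(=O)c1c(Cl)cncc1Cl)N1CCC(C(Oc2cccnc2)c2ccc(Br)cc2)CC1`, is the compound that is not yet measured. Going from compound 3 to compound 4 the change is pyridin-3-yl in place of hydrogen on an oxygen on a saturated carbon. Among the measured compounds shown here, the only measured step, that from compound 1 to compound 3, concerns a different part of the molecule and says nothing about an aryl group on this oxygen. The pair of values for compound 2 and compound 3 is the only hint: the compound that carries an aromatic ring on this oxygen has the lower number. Compound 4 is therefore expected to show a lower number than compound 3, a step of about a 4.0-fold lower number from compound 3 to compound 4 (0.60 log units; beyond the scatter), though the size is uncertain. Compound 4 is estimated to give about 50000 nM in this assay, within a range of 15000 nM to 200000 nM.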

Compound 4, half-maximal cytotoxic concentration: 32500 nM
Compound 4: middle estimate off by 1.5-fold (0.19 log units), on the high side; the range from low to high includes it.
By their numbers in this assay, from the lowest: compound 2; then compound 4; then compounds 1 and 3 (each within the scatter of the next).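

In this assay, hydroxy replaced by (pyridin-3-yl)oxy gives a 6.1-fold lower number from compound 3 to compound 4 (0.78 log units; beyond the scatter), the first single change measured on this oxygen, and it shows directly that substitution here lowers the number beyond the scatter for this pair. Among these compounds, the only earlier single step, a 1.0-fold higher number from compound 1 to compound 3 (0.02 log units; within the scatter), touched the same saturated carbon and left the number within the scatter, so the two changes at this part of the molecule now read differently: one moves the read-out and the other does not. Nothing at hand accounts for the size of the new step.

A phenyl or a methyl group on this oxygen would show whether the lower number goes with the ring nitrogen, with any aromatic ring, or with any group at all in place of the hydrogen. As far as these compounds go, compound 2 differs from compound 4 in two places, so the share of its nitrile-bearing ring and the share of its trifluoromethyl group remain unseparated, and whether the step carries over from the bromo compounds to the trifluoromethyl compounds is also open.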